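Morpholin-4-yl for pyrrolidin-1-yl at the thiocarbonyl carbon

The source may hold more compounds than are shown below. What is called first, only, known or untested is meant among the compounds shown, and "the series" means these compounds.

Measured in a functional assay on MDA-MB-435S cells (Homo sapiens) for antiproliferative activity, read by MTT assay, with a stated time of 72 h; on this read-out higher numbers stand for weaker inhibition and lower numbers for stronger inhibition:
compound 1 `COc1ccc2occ(CSC(=S)N3CCOCC3)c(=O)c2c1`: > 40000 nM, a limit of the assay
compound 2 `COc1ccc2occ(CSC(=S)N3CCCC3)c(=O)c2c1`: 1800 nM
compound 3 `O=c1c(Cl)c(CSC(=S)N2CCCC2)oc2ccccc12`: 1800 nM

Compound 2 and compound 3 carry different cores; how the two cores differ is not broken down here. In this assay compound 3 is level with compound 2 at the digits given, within the scatter.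

The change morpholin-4-yl in place of pyrrolidin-1-yl on a thiocarbonyl carbon occurs twice in the series. Among measured compounds it gives an at least 22-fold higher number from compound 2 to compound 1 (1.34 log units; beyond the scatter). Compound 1 sits at the limit of > 40000 nM in this assay, at which 1 of the 3 values shown sits, so this step is known only as a lower bound.

Compound 4 `O=c1c(Cl)c(CSC(=S)N2CCOCC2)oc2ccccc12` carries the same change, (morpholin-4-yl in place of pyrrolidin-1-yl on a thiocarbonyl carbon), on the core of compound 3, at the same place. Given an at least 22-fold higher number from compound 2 to compound 1 (1.34 log units; beyond the scatter), and compound 3 starting from 1800 nM, compound 4 is expected to move in the same direction, toward a much higher number. The step from compound 3 to compound 4 is expected to be a 22-fold higher number from compound 3 to compound 4 (1.35 log units; beyond the scatter). Compound 4 is estimated at 40000 nM, expected between 15000 nM and 120000 nM.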

Compound 4, half-maximal inhibitory concentration: 4100 nM
For compound 4 the middle estimate is 9.8-fold (0.99 log units) above the measured one; the whole stated range lies above it.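

In this assay, morpholin-4-yl in place of pyrrolidin-1-yl on a thiocarbonyl carbon gives a 2.3-fold higher number from compound 3 to compound 4 (0.36 log units; beyond the scatter), the same direction as on the core of compound 2 but a much smaller step: the same change on two cores in this assay, an at least 22-fold higher number (1.34 log units; beyond the scatter) from compound 2 to compound 1 and a 2.3-fold higher number (0.36 log units; beyond the scatter) from compound 3 to compound 4, at least 9.7-fold (0.98 log units) apart, beyond the scatter of two such steps

Across these two pairs the direction carries from one core to the other and the size does not, and the pairs do not tell which feature of the cores sets the gap. The earlier step is only a lower bound, as compound 1 stands at a limit of the assay: the limit of > 40000 nM in this assay, at which 1 of the 4 values shown sits.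

Still open, as far as these compounds go, is whether other amines on the thiocarbonyl carbon, such as piperidin-1-yl or dimethylamino, track pyrrolidin-1-yl or morpholin-4-yl on either core. A core differing from either core in one place only could help separate which difference governs the size of the step.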